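Ring amide nitrogen substituent: pyridinyl to fluorophenyl

The source may hold more compounds than are shown below. What is called first, only, known or untested is meant among the compounds shown, and "the series" means these compounds.

Compound 2 `O=C(NCCCCc1ccccc1)c1cccc(C2SCC(=O)N2c2ccccn2)c1` gives the lowest number of the three measured in a functional assay on HOS-TE85 cells (Homo sapiens) for inhibition, read by CCK-8 assay, with a stated time of 72 h (a higher number here means a weaker inhibitor, a lower number a stronger inhibitor), at 19.7 nM. Its nearest neighbour is compound 1 `O=C(NCCCCn1cccn1)c1cccc(C2SCC(=O)N2c2ccccn2)c1`, which in this assay gives 60.3 nM; the change is a 3.1-fold lower number from compound 1 to compound 2 (0.49 log units; beyond the scatter). Compound 3 `CCOC(=O)c1sc(N2C(=O)CSC2c2cccc(C(=O)NCCCCn3cccn3)c2)nc1C` gives 430 nM in this assay, the weakest of the set, and differs from compound 1 by a 7.1-fold higher number from compound 1 to compound 3 (0.85 log units; beyond the scatter).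

Compound 4 `O=C(NCCCCc1ccccc1)c1cccc(C2SCC(=O)N2c2cccc(F)c2)c1` has not been measured. It differs from compound 2 as follows: 3-fluorophenyl in place of pyridin-2-yl on an amide-type nitrogen in a ring. Among the measured compounds shown here, the only measured step at the same place is the one from compound 1 to compound 3, where the pyridin-2-yl was also exchanged for another ring on the amide-type nitrogen in the ring, with a 7.1-fold higher number from compound 1 to compound 3 (0.85 log units; beyond the scatter). For the measured compounds named here, that entering group is quite unlike 3-fluorophenyl, so it gives the direction of risk rather than a direct template; no measured pair shows a phenyl-type ring at this position. The expectation is therefore a modest loss in this assay, smaller than that seen for compound 3, and possibly within the scatter.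

Compound 4 is estimated at 40 nM in this assay, with a likely range of 12 nM to 150 nM, which corresponds to an expected step of a 2.0-fold higher number from compound 2 to compound 4 (0.31 log units; beyond the scatter).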

Compound 4, half-maximal inhibitory concentration: 32.4 nM
For compound 4 the middle estimate is 1.2-fold (0.09 log units) above the measured one; low and high end bracket the measured number.
By their numbers in this assay, from the lowest: compounds 2, 4 and 1 (each within the scatter of the next, the first and the last beyond it); then compound 3.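

In this assay, the exchange at the amide-type nitrogen in the ring gives a 1.6-fold higher number from compound 2 to compound 4 (0.22 log units; within the scatter), so compound 2 and compound 4 cannot be told apart, even though pyridin-2-yl carries a ring nitrogen and a hydrogen-bond acceptor and 3-fluorophenyl, a ring of carbon only, carries neither. Among the compounds shown here, the only earlier exchange at this position was a 7.1-fold higher number from compound 1 to compound 3 (0.85 log units; beyond the scatter), so the new pair shows that replacing pyridin-2-yl does not by itself bring a step beyond the scatter, and that a ring nitrogen is not required here for a value in the range of compound 2. No measurement bears on why these two rings read alike, and nothing available explains the larger step seen with the 5-(ethoxycarbonyl)-4-methyl-1,3-thiazol-2-yl group.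

On these data alone, the contribution of the fluorine remains open, as an unsubstituted phenyl ring at this position would separate it from the loss of the ring nitrogen. Also open, as far as these compounds go, is how far the position tolerates a ring carrying a carboxylic acid or an amine, and whether 3-fluorophenyl behaves the same with 1H-pyrazol-1-yl at the end of the chain.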